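A few compounds are considered here, and "the series" means these few. Any claim that something is new, unique, unknown or untested is made for them only; others in the source may bear on it.

Of the compounds shown here, three built on one shared core have been tested in a toxicity assay on HepG2 cells (Homo sapiens) for inhibition, read by CellTiter-Glo, with a stated time of 48 h; a higher number here means a weaker inhibitor, a lower number a stronger inhibitor. Compound 1 `COc1ccc2nc(C)cc(OCC(=O)Nc3ccc(Cl)c(OC)c3)c2c1` returns only the limit of the assay, giving > 100000 nM in this assay. Compound 2 `COc1ccc2nc(C)cc(OCC(=O)Nc3ccc(F)cc3)c2c1` gives a proper number, 63100 nM in this assay. Compound 3 `COc1ccc2nc(C)cc(OCC(=O)Nc3ccncn3)c2c1` again returns only a limit, > 100000 nM in this assay. The step of an at least 1.5-fold lower number from compound 1 to compound 2 (0.19 log units; that floor lies within the scatter) has a floor lying within the scatter, and an at least 1.5-fold higher number from compound 2 to compound 3 (0.19 log units; that floor lies within the scatter) is likewise only a floor within the scatter; the step that the two limits leave unreadable from compound 1 to compound 3 cannot be sized at all because both of its ends sit at the limit of > 100000 nM in this assay, at which 2 of the 3 values shown sit. Compound 4 `COc1ccc2nc(C)cc(OCC(=O)Nc3cc(C)nc(C)n3)c2c1` differs from compound 3 by 2,6-dimethylpyrimidin-4-yl in place of pyrimidin-4-yl on an amide-type nitrogen. Every step measured so far either passes through the limit or stays within the scatter, so no direction can be read from them, and the change is made on a group that in compound 3 already gives a limit. The expected step of a number no higher from compound 3 to compound 4 (the limit leaves the size open) is therefore one that stays within the scatter. Compound 4 is estimated at 100000 nM, within a range from 40000 nM to 300000 nM, and will quite probably again be reported only as a limit.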

Compound 4, half-maximal inhibitory concentration: > 100000 nM
Compound 4 was reported as a limit; the forecaster's own chance of this, stated with the estimate: 70%; the middle value lies on the limit itself.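

With 2,6-dimethylpyrimidin-4-yl on the amide-type nitrogen, a third group at this position gives only a limit in this assay, so the readings gather at one end of the scale: the limit of > 100000 nM in this assay, at which 3 of the 4 values shown sit. The steps among compound 1, compound 3 and compound 4 cannot be read, so any effect of adding the methyl groups to the pyrimidine stays hidden. Within the data shown here, the one readable new step, an at least 1.5-fold higher number from compound 2 to compound 4 (0.19 log units; that floor lies within the scatter), is no firmer than the earlier ones, and only one of the four compounds has a real number so far.

As far as these compounds go, whether any group on this nitrogen can bring the number clearly down remains open. A phenyl ring carrying an amine or a carboxylic acid, or a plain alkyl chain in place of the ring, could show how far the reading moves.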